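A few compounds are considered here, and "the series" means these few. Any claim that something is new, unique, unknown or untested is made for them only; others in the source may bear on it.

Measured compounds:
compound 1 `CC1CN(c2cnc3cnn(C(C)c4ccc(Cl)cc4Cl)c3n2)CCC1N1CCCCC1` gives 68 ng.h/mL in an ADME assay on the whole organism (Rattus norvegicus), at a dose of 0.5 mg/kg by the intravenous route; a higher number here means more compound in the circulation at the dose given, a lower number less compound in the circulation
compound 2 `CC1CN(c2cnc3c(C(N)=O)nn(C(C)c4ccc(Cl)cc4Cl)c3n2)CCC1N1CCCCC1` gives 82 ng.h/mL in this assay

Among the measured compounds shown here, compound 2 stands alongside compound 1: the one step on record, a 1.2-fold higher number from compound 1 to compound 2 (0.08 log units; within the scatter), lies within the scatter, so the two numbers cannot be told apart and neither compound can be placed above the other.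

Compound 3 `CC1CN(c2cnc3c(C(F)(F)F)nn(C(C)c4ccc(Cl)cc4Cl)c3n2)CCC1N1CCCCC1` is the next structure to be read in this assay. It differs from compound 2 in one place: trifluoromethyl in place of carbamoyl on an aromatic carbon. For the measured compounds named here, the only measured step concerns the same aromatic carbon, carbamoyl in place of hydrogen, and was within the scatter. Going by the values given here, no measured step exchanges carbamoyl for trifluoromethyl, so nothing here argues for a move in either direction beyond the scatter. On that basis compound 3 is expected near compound 2, with an estimated step of a 1.0-fold lower number from compound 2 to compound 3 (0.01 log units; within the scatter). The expected value for compound 3 is 80 ng.h/mL, within a range of 35 ng.h/mL to 180 ng.h/mL.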

Compound 3, area under the concentration-time curve: 148 ng.h/mL
Beside the measured number, compound 3's estimate is 1.9-fold (0.27 log units) below it, within the range that was stated.
By their numbers in this assay, from the lowest: compounds 1, 2 and 3 (each within the scatter of the next, the first and the last beyond it).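

In this assay this aromatic carbon gives its first step beyond the scatter, a 2.2-fold higher number from compound 1 to compound 3 (0.34 log units; beyond the scatter), a modest change with trifluoromethyl in place of hydrogen. Exchanging carbamoyl for trifluoromethyl at the same carbon gives a 1.8-fold higher number from compound 2 to compound 3 (0.26 log units; within the scatter), which lies within the scatter, so the two substituted compounds cannot be told apart, and of the three compounds only the hydrogen and trifluoromethyl pair separates. Nothing available explains this separation.

Going by these compounds, it remains open whether other groups on this carbon, such as a nitrile, an amine, a carboxylic acid or a longer chain, would stay with compound 1 or with compound 3. Also open, on these data alone, is whether the modest step from hydrogen to trifluoromethyl would carry over to other changes elsewhere on the shared core.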